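Adding a Third Methoxy Group to a Benzyl Amine

The compounds below may be only part of what the source reports. "The series", "measured", "known", "first", "only" and "open" are said of these compounds alone.

Compound 1 `Nc1cc(N)c2nc(-c3ccccc3)c(NCc3ccc(Cl)c(Cl)c3)nc2c1` and compound 2 `COc1ccc(CNc2nc3cc(N)cc(N)c3nc2-c2ccccc2)cc1OC` share one core and differ only in the group carried on the saturated chain carbon bound to the ring nitrogen. In a functional assay on HOP-62 cells (Homo sapiens) for inhibition, read by sulforhodamine B assay, with a stated time of 48 h (on this read-out lower numbers stand for higher toxicity in this test and higher numbers for lower toxicity in this test), compound 1 gives 64600 nM, and in the same test compound 2 gives 64600 nM. The step of no change at the digits printed from compound 1 to compound 2 (within the scatter) shows that swapping the 3,4-dichlorophenyl for a 3,4-dimethoxyphenyl left the read-out where it was. Compound 2 therefore stands level with compound 1 on the numbers shown, with no measured neighbour that separates from it.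

Compound 3 `COc1cc(CNc2nc3cc(N)cc(N)c3nc2-c2ccccc2)cc(OC)c1OC` carries a further change on that same ring: methoxy in place of hydrogen on an aromatic carbon. Going by the values given here, the only step that bears on this change is the one from compound 1 to compound 2, which was flat, so a methoxy-bearing ring in this place has so far not moved this assay. For compound 3 no step beyond the scatter is expected in this assay, the estimated step being no change at the digits printed from compound 2 to compound 3 (within the scatter). Compound 3 is accordingly estimated at 64600 nM, within a range of 30000 nM to 130000 nM.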

Compound 3, concentration lethal to 50% of the cells: < 50200 nM
Compound 3 ended at the assay's limit; the forecaster's own chance of this, stated with the estimate: 25%; middle value at least 1.2-fold (0.10 log units) away from the limit.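

In this assay compound 3 gives < 50200 nM, and this is a limit of the assay, not a number. Adding the methoxy group on the aromatic carbon, ortho to a methoxy group, therefore gives an at least 1.2-fold lower number from compound 2 to compound 3 (0.10 log units; that floor lies within the scatter), so this change is the first here to point toward a lower number, yet it cannot be told apart from no change, and the true size of the step stays unknown. The earlier step, no change at the digits printed from compound 1 to compound 2 (within the scatter), could be read at the printed digits, whereas this one has only a floor, and it is the one reading of its kind among the compounds shown: the limit of < 50200 nM in this assay, at which 1 of the 3 values shown sits.

Going by these compounds, how the read-out responds to other groups on this aromatic carbon, such as a hydroxyl, a fluorine or an amine, remains open. The compounds shown also leave open whether a further chlorine on the ring of compound 1 would behave like this methoxy group, and how a longer chain between that ring and the ring nitrogen would read.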